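Phenyl in place of a branched alkyl: expected half-life

The compounds below may be only part of what the source reports. "The series", "measured", "known", "first", "only" and "open" are said of these compounds alone.

Compound 1, `CC(C)CCn1nc(CC2CCC2)c(O)c(C2=NS(=O)(=O)c3cc(NS(C)(=O)=O)ccc3N2)c1=O`, was measured in an in vitro ADME assay on microsomes from liver (Homo sapiens) for metabolic stability, tested at 5 uM (a lower number here means that the compound disappears faster, a higher number that the compound lasts longer), and gave a half-life of 0.417 h. Compound 2, `CCC(C)(C)Cn1nc(-c2cccs2)c(O)c(C2=NS(=O)(=O)c3cc(NS(C)(=O)=O)ccc3N2)c1=O`, was measured in this assay as well, and for compound 2 the result is a limit rather than a number: > 1 h. This is the limit of > 1 h in this assay, at which 1 of the 2 values shown sits, so where compound 2 stands is known only as that limit. Among the compounds with values here, no step between compound 1 and compound 2 has been worked out; the two results are simply the number for compound 1 and the limit for compound 2.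

Compound 3, `CS(=O)(=O)Nc1ccc2c(c1)S(=O)(=O)N=C(c1c(O)c(-c3cccs3)nn(Cc3ccccc3)c1=O)N2`, has not yet been measured. It differs from compound 2 in one place: phenyl in place of 1,1-dimethylpropyl on a saturated chain carbon bound to an aromatic nitrogen.

Since compound 2 offers only a limit, the step from compound 2 to compound 3 in this assay is expected to be an at least 1.2-fold lower number from compound 2 to compound 3 (0.09 log units; that floor lies within the scatter), in the downward direction, though it is expected to stay near the edge of the scatter rather than far beyond it. Compound 3 is therefore expected to give about 0.8 h in this assay, with the likely range running from 0.35 h to 2 h.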

Compound 3, half-life: > 1 h
Compound 3 was reported as a limit; the forecaster's own chance of this, stated with the estimate: 35%; at least 1.2-fold (0.09 log units) between middle value and limit.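

In this assay compound 3 gave > 1 h, which is a limit and not a number. Within the data shown here, compound 2 is also reported as a limit, so no step from compound 2 to compound 3 can be read, because both results rest on the same limit: the limit of > 1 h in this assay, at which 2 of the 3 values shown sit. On these data alone, the actual half-lives of compound 2 and compound 3, and so whether phenyl in place of 1,1-dimethylpropyl shifts the half-life in either direction, stay open.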